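A few compounds are considered here, and "the series" means these few. Any claim that something is new, unique, unknown or untested is made for them only; others in the source may bear on it.

Measured compounds: compound 1 `Cc1cc(Nc2ccn(Cc3cccc4ccccc34)n2)n2nc(SCc3ccc(Br)cc3)nc2n1`, 3240 nM; compound 2 `Cc1cc(Nc2cc(-c3ccccc3)[nH]n2)n2ncnc2n1`, 21700 nM; compound 3 `Cc1cc(Nc2cc(-c3ccc(Cl)cc3)[nH]n2)n2nc(SCc3ccc(Br)cc3)nc2n1`, 2780 nM.

In a functional assay on MGC-803 cells (Homo sapiens) for inhibition, read by MTT assay, with a stated time of 72 h (on this read-out lower numbers stand for stronger inhibition and higher numbers for weaker inhibition), compound 2 gives 21700 nM, the highest of the three numbers; compound 1 and compound 3, each carrying a sulfanyl group on the shared core, stand well below it, beyond the scatter. Compound 4 `Cc1cc(Nc2cc(-c3ccccc3)[nH]n2)n2nc(SCCc3ccccc3)nc2n1` is not yet measured. It differs from compound 2 by phenethylsulfanyl in place of hydrogen on an aromatic carbon. Within the data shown here, no step between measured compounds is known here, so no measured change can be quoted for this exact exchange. Because compound 1 gives 3240 nM and compound 3 gives 2780 nM, a step toward lower numbers is expected in this assay, of a size beyond the scatter. Compound 4 is therefore estimated at 5000 nM, within 1500 nM to 15000 nM, a step of a 4.3-fold lower number from compound 2 to compound 4 (0.64 log units; beyond the scatter).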

Compound 4, half-maximal inhibitory concentration: 5620 nM
Beside the measured number, compound 4's estimate is 1.1-fold (0.05 log units) below it, and the stated range covers the measured number.
By their numbers in this assay, from the lowest: compounds 3, 1 and 4 (each within the scatter of the next, the first and the last beyond it); then compound 2.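

In this assay, among these compounds, phenethylsulfanyl in place of hydrogen gives a 3.9-fold lower number from compound 2 to compound 4 (0.59 log units; beyond the scatter), a modest step and the first change at this aromatic carbon that can be read on its own. Compound 1 and compound 3 also carry a sulfanyl group there, but they differ from the other compounds in more than one place. Nothing measured here accounts for the step. The compounds shown leave open whether methylsulfanyl, an amine or a longer chain on this carbon would lower the number as far, and whether the entering group's aromatic ring is needed.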